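Branching Beside the Amine: Expecting Compound 4

The compounds below may be only part of what the source reports. "The series", "measured", "known", "first", "only" and "open" are said of these compounds alone.

Measured so far in a functional assay on CCRF-CEM cells for antagonist activity at C-X-C chemokine receptor type 4 (Homo sapiens), read by calcium flux, with stated times of 25 min and 90 s; a lower number here means a stronger inhibitor, a higher number a weaker inhibitor:
compound 1 `CCN(C[C@H]1Cc2c(cccc2N2CCNCC2)CN1)[C@H]1CCCc2cccnc21` gives 14.8 nM
compound 2 `CC(C)N(C[C@H]1Cc2c(cccc2N2CCNCC2)CN1)[C@H]1CCCc2cccnc21` gives 364 nM
compound 3 `CCCN(C[C@H]1Cc2c(cccc2N2CCNCC2)CN1)[C@H]1CCCc2cccnc21` gives 32.2 nM

Compound 3 stands second highest of these three numbers: its nearest neighbour is compound 1, as a 2.2-fold higher number from compound 1 to compound 3 (0.34 log units; beyond the scatter) shows, and its furthest is compound 2, as an 11-fold lower number from compound 2 to compound 3 (1.05 log units; beyond the scatter) shows. Compound 4 `c1cnc2c(c1)CCC[C@@H]2N(CC1CCCCC1)C[C@H]1Cc2c(cccc2N2CCNCC2)CN1` differs from compound 3 by cyclohexyl in place of ethyl on a saturated chain carbon bound to an amine nitrogen. Among the compounds with values here, two measured steps bear on this. Lengthening the chain further from the nitrogen cost little, a 2.2-fold higher number from compound 1 to compound 3 (0.34 log units; beyond the scatter), whereas adding a methyl on the carbon bound to the amine nitrogen cost a great deal, a 25-fold higher number from compound 1 to compound 2 (1.39 log units; beyond the scatter). Compound 4 adds a ring at that same carbon, so a large rise in the number is expected, an 11-fold higher number from compound 3 to compound 4 (1.04 log units; beyond the scatter). Compound 4 is therefore estimated at 350 nM, within 80 nM to 1500 nM.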

Compound 4, half-maximal inhibitory concentration: 715 nM
Compound 4: middle estimate off by 2.0-fold (0.31 log units), on the low side, and the stated range covers the measured number.
By their numbers in this assay, from the lowest: compound 1; then compound 3; then compounds 2 and 4 (each within the scatter of the next).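

Replacing ethyl with cyclohexyl on the saturated chain carbon bound to an amine nitrogen raises the number sharply (a 22-fold higher number from compound 3 to compound 4 (1.35 log units; beyond the scatter)), and the rise is larger still when measured against the shortest chain shown (a 48-fold higher number from compound 1 to compound 4 (1.68 log units; beyond the scatter)). Cyclohexylmethyl and isopropyl on the amine nitrogen cannot be told apart (a 2.0-fold higher number from compound 2 to compound 4 (0.29 log units; within the scatter)), so adding the ring gives a result level with isopropyl, not a further clear loss. As far as these compounds go, whether a smaller ring such as cyclopropyl, or a chain ending in an amine or a carboxylic acid, would restore the strength of compound 1 remains open. No evidence here explains the loss seen with either group.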